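A few compounds are considered here, and "the series" means these few. Any claim that something is new, unique, unknown or untested is made for them only; others in the source may bear on it.

Within the data shown here, compound 1 `c1ccc2c(c1)CN[C@@H](CN(CCCCNCC1CCSCC1)[C@H]1CCCc3cccnc31)C2` gives 69.6 nM in a functional assay on cells for antagonist activity at C-X-C chemokine receptor type 4 (Homo sapiens), read by fluorescence and calcium flux, with stated times of 25 min and 90 s (a higher number here means a weaker inhibitor, a lower number a stronger inhibitor), the highest of the two numbers so far, though the step of a 1.5-fold lower number from compound 1 to compound 2 (0.18 log units; within the scatter) falls within the scatter, so the two are not separated. Compound 2 `O=S1(=O)CCC(NCCCCN(C[C@H]2Cc3ccccc3CN2)[C@H]2CCCc3cccnc32)CC1` gives 45.5 nM in this assay. Compound 3 `C(=C/CN(C[C@H]1Cc2ccccc2CN1)[C@H]1CCCc2cccnc21)\CNC1CCOCC1` differs from compound 1 by a group of 10 heavy atoms (8 carbon, 1 nitrogen, 1 oxygen; one six-membered non-aromatic ring with 1 hetero atom) in place of a group of 11 heavy atoms (9 carbon, 1 nitrogen, 1 sulfur; one six-membered non-aromatic ring with 1 hetero atom), on a saturated chain carbon bound to an amine nitrogen. Among the measured compounds shown here, the only measured step that bears on this is a 1.5-fold lower number from compound 1 to compound 2 (0.18 log units; within the scatter), a swap of one saturated heterocyclic tail for another on an amine nitrogen, and it was small; the present change is larger but nothing measured gives it a direction. Compound 3 is therefore expected near 65 nM, between 25 nM and 170 nM, meaning an estimated step of a 1.1-fold lower number from compound 1 to compound 3 (0.03 log units; within the scatter).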

Compound 3, half-maximal inhibitory concentration: 15.5 nM
Compound 3: middle estimate off by 4.2-fold (0.62 log units), on the high side; measured number outside the range, below it.
By their numbers in this assay, from the lowest: compound 3; then compounds 2 and 1 (each within the scatter of the next).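

In this assay, the change at this saturated chain carbon bound to an amine nitrogen gives a 4.5-fold lower number from compound 1 to compound 3 (0.65 log units; beyond the scatter) and thus shows that this place can respond beyond the scatter. The entering 3-((oxan-4-yl)amino)prop-1-en-1-yl group differs from the leaving group in more than one feature, including its double bond outside aromatic rings and its ring oxygen in place of sulfur. No evidence at hand accounts for the step. Open is which feature carries it: would a saturated chain bearing the same oxan-4-yl amine keep it, and would a piperidine ring in the tail?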